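A benzyl swap at the edge of measurement

The source may report more compounds than this note shows. Statements on the series, on what has been measured and on what is new or still open speak of the compounds shown alone.

- Compound 1 `COC(=O)c1ccc(NCc2cncn2Cc2ccc(Cl)cc2)cc1-c1ccccc1`: 25000 nM
- Compound 2 `CN(C)c1ccc(NCc2cncn2Cc2ccc(-c3ccccc3)cc2)cc1-c1ccccc1`: > 1000 nM
- Compound 3 `CC(C)c1ccc(Cn2cncc2CNc2ccc(-c3nc4ccccc4s3)c(-c3ccccc3)c2)cc1`: > 1000 nM

All three compounds were tested in a toxicity assay on NIH3T3 cells (Mus musculus) for cytotoxicity, read by resazurin assay; a lower number here means that less compound is needed, a higher number that more compound is needed for the effect. Among the compounds with values here, compound 1 is the only one with a true number, 25000 nM. Compound 2 gave only a limit, > 1000 nM. Compound 3 also gave only a limit, > 1000 nM, and not a number. Going by these compounds, the data are therefore marked by the limit of > 1000 nM in this assay, at which 2 of the 3 values shown sit, and the exact standing of compound 3 is unknown.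

Compound 4 `Fc1ccc(Cn2cncc2CNc2ccc(-c3nc4ccccc4s3)c(-c3ccccc3)c2)c(F)c1` changes one place in compound 3: 2,4-difluorophenyl in place of 4-isopropylphenyl on a saturated chain carbon bound to an aromatic nitrogen. In words, 2,4-difluorophenyl stands in place of 4-isopropylphenyl on a saturated chain carbon bound to an aromatic nitrogen. Both groups are a six-membered aromatic ring of carbon only.

Within the data shown here, no measured pair here differs in just one place, so the size of this change in this assay has no direct precedent. The expected step that the limit leaves unreadable from compound 3 to compound 4 is small, with no firm direction. This expectation starts from the limit of compound 3, > 1000 nM. The assay may well report only a limit again. For compound 4 the estimated value is 3000 nM, with an expected range of 1000 nM to 25000 nM.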

Compound 4, half-maximal effective concentration: > 1000 nM
Compound 4 gave a limit, no number; the forecaster's own chance of this, stated with the estimate: 65%; the middle value lies beyond the limit too.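

Compound 3 and compound 4 both gave only a limit and no true number, so the step between them cannot be read, and the result stays at the edge of measurement: the limit of > 1000 nM in this assay, at which 3 of the 4 values shown sit.

Going by these compounds, whether 2,4-difluorophenyl in place of 4-isopropylphenyl changes the amount of compound needed in this assay, and in which direction, remains open.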